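This account rests on a few compounds, and the source may have more. Where it says the series, first, only, none or still open, it means among the compounds named here.

Of the compounds shown here, two that share one core have been tested in an assay on membranes from brain for displacement of a labelled ligand from Sigma non-opioid intracellular receptor 1 (Cavia porcellus); a higher number here means a weaker inhibitor, a lower number a stronger inhibitor. Compound 1 `CCCc1ccc2c(c1)sc(=O)n2CCN1CCCCC1` carries a propyl chain and in this assay compound 1 gives 0.6 nM. Compound 2 `CCCCc1ccc2c(c1)sc(=O)n2CCN1CCCCC1` carries a butyl chain instead, and in this assay compound 2 gives 3.7 nM. Of these two numbers, compound 2 stands at the higher one; its nearest neighbour is compound 1, reached by a 6.2-fold higher number from compound 1 to compound 2 (0.79 log units; beyond the scatter).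

Compound 3 `O=C(c1ccc2c(c1)sc(=O)n2CCN1CCCCC1)C1CC1` has not yet been measured. It differs from compound 2 in one place: cyclopropylcarbonyl in place of butyl on an aromatic carbon. Among the compounds with values here, the only measured step that bears on this change is the one from compound 1 to compound 2, which altered the same chain and was a 6.2-fold higher number from compound 1 to compound 2 (0.79 log units; beyond the scatter), a modest shift but beyond the scatter. Within the data shown here, no measured pair speaks to a carbonyl or a three-membered ring in this position, so the direction of the coming step is open. A shift of roughly similar size in this assay is therefore expected for compound 3, amounting to a 1.6-fold higher number from compound 2 to compound 3 (0.21 log units; within the scatter). The estimate for compound 3 in this assay is 6 nM, with a range from 1.5 nM to 25 nM.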

Compound 3, inhibition constant: > 1000 nM
Compound 3: only a limit was reported; the forecaster's own chance of this, stated with the estimate: 2%; middle value at least 160-fold (2.22 log units) away from the limit.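

In this assay, putting cyclopropylcarbonyl in place of the butyl chain on this aromatic carbon gives an at least 270-fold higher number from compound 2 to compound 3 (2.43 log units; beyond the scatter), and putting it in place of the propyl chain gives an at least 1600-fold higher number from compound 1 to compound 3 (3.22 log units; beyond the scatter). Within the data shown here, both steps dwarf the only earlier change at this position, a 6.2-fold higher number from compound 1 to compound 2 (0.79 log units; beyond the scatter), so the two chains alone gave no sign that a single replacement here could remove nearly all of the measured binding, and this position proves far less forgiving than that modest step suggested. The reading for compound 3 is a limit and not an exact number: the limit of > 1000 nM in this assay, at which 1 of the 3 values shown sits.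

The entering group brings a carbonyl and a three-membered ring together, so the compounds shown cannot tell whether either part alone accounts for the loss; a plain cyclopropyl group with no carbonyl and a butanoyl group with a carbonyl but no ring would pull the two apart. Going by these compounds, it also remains open how an ethyl group or a pentyl chain on this carbon would fare, and so whether the propyl chain of compound 1 sits at a true optimum in chain length.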